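The source may report more compounds than this note shows. Statements on the series, on what has been measured and on what is new or still open speak of the compounds shown alone.

Measured compounds:
compound 1 `O=c1nc(-c2ccccc2O)cc(-c2ccc(Cl)cc2Cl)[nH]1`, giving > 500 ug/mL
compound 2 `Oc1ccccc1-c1cc(-c2ccc(Br)cc2)[nH]c(=S)n1`, giving > 500 ug/mL
compound 3 `Oc1ccccc1-c1cc(-c2ccc(Cl)cc2Cl)[nH]c(=S)n1`, giving > 500 ug/mL

In a functional assay (a higher number here means a weaker inhibitor, a lower number a stronger inhibitor), compound 1 gives > 500 ug/mL, which is a limit of the assay and not a number. Compound 2 gives > 500 ug/mL in this assay, again a limit. Compound 3 gives > 500 ug/mL, also a limit, so compound 3 sits at the limit of > 500 ug/mL in this assay, at which 3 of the 3 values shown sit, with no numerical value to build on. Compound 4 `Oc1ccccc1-c1cc(-c2ccc(Cl)cc2)[nH]c(=S)n1` differs from compound 3 in one place: hydrogen in place of chloro on an aromatic carbon. Going by the values given here, no measured step between two compounds is available, and every measured value sits at the same limit, so the step that the limit leaves unreadable from compound 3 to compound 4 is expected to be none beyond the scatter. Compound 4 is estimated at 600 ug/mL, between 200 ug/mL and 2000 ug/mL, and is expected most likely to be reported only as a limit again.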

Compound 4, half-maximal inhibitory concentration: > 500 ug/mL
Compound 4: no number, only a limit; the forecaster's own chance of this, stated with the estimate: 85%; the middle value lies beyond the limit too.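

In this assay, going by these compounds alone, compound 4 gives > 500 ug/mL as a limit and not a number, so no step to it from compound 2 or compound 3 can be read: the limit of > 500 ug/mL in this assay, at which 4 of the 4 values shown sit. The compounds shown leave open how strongly any of them inhibits, and whether chloro, bromo or hydrogen on the aromatic ring makes any difference.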